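The source may hold more compounds than are shown below. What is called first, only, known or untested is meant among the compounds shown, and "the series" means these compounds.

Two compounds of the series have been run in an assay for inhibition of Rap guanine nucleotide exchange factor 3 (Homo sapiens), read by fluorescence, tested at 10 uM; a lower number here means a weaker effect, a higher number a stronger effect of the compound at the concentration tested. Compound 1 `CC1CCc2c(ccc(F)c2Br)N1C=O` gives 15.8%, and compound 2 `CC1CCc2c(cc(Br)c(F)c2Br)N1` gives 40.8%. Compound 2 stands highest of the two numbers; compound 1 is the nearest and sits lower, a gap beyond the scatter. Within the data shown here, the two differ in more than one place, so no single step can be drawn from them.

Compound 3 `CC(=O)N1c2cc(Br)c(F)c(Br)c2CCC1C` follows from compound 2 by one change: acetyl in place of hydrogen on a nitrogen on an aromatic ring in a ring. Among the measured compounds shown here, no step of this kind between measured compounds is available, so the size of the change in this assay is open. A moderate downward step is expected, a number 12.8 percentage points lower from compound 2 to compound 3 (beyond the scatter), with the possibility that the result stays within the scatter of compound 2. Compound 3 is therefore estimated at 28%, within a range from 8% to 48%.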

Compound 3, a percentage reported as inhibition, at one concentration (the size of the read-out at that concentration, not a potency): 8.7%
The estimate for compound 3 lay 19.3 percentage points above the measured number; the range from low to high includes it.
By their numbers in this assay, from the lowest: compounds 3 and 1 (each within the scatter of the next); then compound 2.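

In this assay, among these compounds, acetyl in place of hydrogen on a nitrogen on an aromatic ring in a ring gives a large fall, a number 32.1 percentage points lower from compound 2 to compound 3 (beyond the scatter), the first single change whose size can be read. For this pair, the read-out is therefore sensitive to what sits on this nitrogen, with the unsubstituted nitrogen of compound 2 giving the higher number, though one pair cannot show whether this extends to other groups. Nothing available explains why the read-out falls with this change.

Going by these compounds, it remains open whether an ethyl chain, a methanesulfonyl group or an aminoacetyl group on this nitrogen would give a fall of similar size. Compound 1 and compound 3 differ in more than one place, so the separate contributions of their differences cannot be read from them.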